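Swapping Phenoxy for Dimethylamino on a Pyrazole Series

The source may report more compounds than this note shows. Statements on the series, on what has been measured and on what is new or still open speak of the compounds shown alone.

Compound 3 `Cc1cc(O)cc(-c2nn(CC#N)cc2-c2ccnc(-c3ccc(Oc4ccccc4)cc3)c2)c1`: 5380 nM
Compound 2 `COc1cc(C)cc(-c2nn(CC#N)cc2-c2ccc(-c3cccc(C(C)=O)c3)nc2)c1`: 87400 nM
Compound 1 `COc1cc(C)cc(-c2c(-c3ccnc(-c4ccc(C(C)=O)cc4)c3)cnn2CC#N)c1`: > 100000 nM

In a functional assay on HCT-116 cells (Homo sapiens) for inhibition, read by sulforhodamine B assay, with a stated time of 48 h (a lower number here means that less compound is tolerated, a higher number that more compound is tolerated), compound 3 gives the lowest of the two real numbers. Compound 2 sits higher, beyond the usual scatter. For compound 1 the readout is the limit of > 100000 nM in this assay, at which 1 of the 3 values shown sits, a limit rather than a number. Compound 4 `Cc1cc(O)cc(-c2nn(CC#N)cc2-c2ccnc(-c3ccc(N(C)C)cc3)c2)c1` keeps the shared core of compound 3 and changes one group: dimethylamino in place of phenoxy on an aromatic carbon. Going by the values given here, no measured pair shows a step of exactly this kind, so its size cannot be read from the data. A modest rise in this assay, or none beyond the scatter, seems the most likely outcome. Compound 4 is expected to give about 12000 nM, between 3000 nM and 50000 nM, which amounts to an expected step of a 2.2-fold higher number from compound 3 to compound 4 (0.35 log units; beyond the scatter).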

Compound 4, concentration lethal to 50% of the cells: 41900 nM
Compound 4: the middle estimate sits 3.5-fold (0.54 log units) below what was measured, and the stated range covers the measured number.
By their numbers in this assay, from the lowest: compound 3; then compound 4; then compound 2. At a limit, above all of these: compound 1.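

Going by these compounds alone, on this aromatic carbon, dimethylamino in place of phenoxy gives a 7.8-fold higher number from compound 3 to compound 4 (0.89 log units; beyond the scatter) in this assay and is the first one-place change that can be read. Compound 3 and compound 4 share everything else, so this gap belongs to this one group alone. No measurement shown explains the step.

From the compounds shown here alone, whether the higher number follows the lost aromatic ring or the entering nitrogen stays open. A methoxy group, an anilino group or a plain hydrogen at this place would help separate the two.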